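Dropping the aryl methyl of compound 1

The source may report more compounds than this note shows. Statements on the series, on what has been measured and on what is new or still open speak of the compounds shown alone.

Compound 1 `Cc1ccc2c(=O)c(CSC(=S)N3CCCCC3)coc2c1` stands at the assay ceiling in a functional assay on HeLa cells (Homo sapiens) for antiproliferative activity, read by MTT assay, with a stated time of 72 h; a lower number here means a stronger inhibitor, a higher number a weaker inhibitor: the reported > 25000 nM is a limit, not a number (the limit of > 25000 nM in this assay, at which 1 of the 2 values shown sits). Within the data shown here, compound 2 `Cc1ccc2c(=O)c(CSC(=S)N(C(C)C)C(C)C)coc2c1` gives 1400 nM in this assay, and the only measured step, an at least 17-fold lower number from compound 1 to compound 2 (1.25 log units; beyond the scatter), exchanges the amine on the thiocarbonyl carbon and leaves the aromatic ring untouched. Compound 3 `O=c1c(CSC(=S)N2CCCCC2)coc2ccccc12` differs from compound 1 by hydrogen in place of methyl on an aromatic carbon. Among the measured compounds shown here, no measured step bears on this change, so the expected step is a step that the limit leaves unreadable from compound 1 to compound 3, none beyond the scatter, with compound 3 most likely reported again as a limit. The estimate for compound 3 is 30000 nM, within 8000 nM to 120000 nM.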

Compound 3, half-maximal inhibitory concentration: 2300 nM
Beside the measured number, compound 3's estimate is 13-fold (1.12 log units) above it; measured number outside the range, below it.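

Hydrogen in place of methyl on this aromatic carbon gives an at least 10-fold lower number from compound 1 to compound 3 (1.03 log units; beyond the scatter) in this assay, so the shared core is not silent at this position, whereas the earlier step changed only the amine on the thiocarbonyl carbon. With piperidin-1-yl kept, this single change is enough to give a measured value. The size of the step remains a bound, since compound 1 carries a limit: the limit of > 25000 nM in this assay, at which 1 of the 3 values shown sits.

Still open, going by these compounds, is whether chlorine or methoxy on the same aromatic carbon would read closer to compound 1 or compound 3. Also open, on these data alone, is whether this change gives a similar step with diisopropylamino on the thiocarbonyl carbon.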